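This account rests on a few compounds, and the source may have more. Where it says the series, first, only, none or still open, it means among the compounds named here.

Measured compounds:
compound 1 `O=C1NCCN1c1ccc(S(=O)(=O)Nc2cccc(Oc3ccccc3)c2)cc1` with 200 nM;
compound 2 `COc1cccc(NS(=O)(=O)c2ccc(N3CCNC3=O)cc2)c1` with 120 nM;
compound 3 `CC(C)(C)c1cc(NS(=O)(=O)c2ccc(N3CCNC3=O)cc2)cc(C(C)(C)C)c1`, whose value is a limit of the assay, > 1000 nM.

In a functional assay on HT-29 cells (Homo sapiens) for antiproliferative activity, read by sulforhodamine B assay, with a stated time of 48 h (on this read-out lower numbers stand for stronger inhibition and higher numbers for weaker inhibition), compound 2 has the lowest of the two numbers shown, with compound 1 nearest: the step of a 1.7-fold lower number from compound 1 to compound 2 (0.22 log units; within the scatter) lies within the scatter. Compound 4 `Cc1ccc(C)c(NS(=O)(=O)c2ccc(N3CCNC3=O)cc2)c1` differs from compound 2 in one place: 2,5-dimethylphenyl in place of 3-methoxyphenyl on a sulfonamide nitrogen. Among the compounds with values here, the only measured step, from compound 1 to compound 2, changed a group on the same aryl ring and was small. For compound 4 the expected step is therefore modest, a 2.5-fold higher number from compound 2 to compound 4 (0.40 log units; beyond the scatter), allowing that the limit of compound 3 the limit of > 1000 nM in this assay, at which 1 of the 3 values shown sits, warns of weaker numbers. Compound 4 is estimated at 300 nM, ranging from 100 nM to 1500 nM.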

Compound 4, half-maximal inhibitory concentration: 46 nM
For compound 4 the middle estimate is 6.5-fold (0.81 log units) above the measured one, outside the stated range (below it).
By their numbers in this assay, from the lowest: compound 4; then compounds 2 and 1 (each within the scatter of the next). At a limit, above all of these: compound 3.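

In this assay the group on the sulfonamide nitrogen is now seen to move the number beyond the scatter, with a 2.6-fold lower number from compound 2 to compound 4 (0.42 log units; beyond the scatter) for this change. The entering 2,5-dimethylphenyl is all carbon and has no hydrogen-bond acceptor, so the oxygen of 3-methoxyphenyl is not required for the activity of compound 4. Nothing shown gives a cause for this step.

Open is whether both methyl groups of compound 4 are needed, since a phenyl with only one is not among these compounds. Also open, from the compounds shown here alone, is how an amine or a carboxylic acid on this ring would fare.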